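The source may report more compounds than this note shows. Statements on the series, on what has been measured and on what is new or still open speak of the compounds shown alone.

In a functional assay on A2780 cells (Homo sapiens) for inhibition, read by sulforhodamine B assay, with a stated time of 3 days (a higher number here means a weaker inhibitor, a lower number a stronger inhibitor), three compounds have been measured so far. Compound 1 (`O=C1Nc2ccc(F)cc2/C1=C\C(=O)c1ccc(O)cc1F`) gives 1580 nM, compound 2 (`O=C1Nc2ccc(F)cc2/C1=C\C(=O)c1ccc[nH]1`) gives 2170 nM, and compound 3 (`CN1CCN(c2cccc(N/C=C3\C(=O)Nc4ccc(NC(=O)c5cccc(F)c5)cc43)c2)CC1`) gives 2910 nM. Compound 3 therefore stands level with the other two, since its value lies within the usual scatter of both and the three cannot be ranked.

Compound 4 (`CC(C)CC(=O)Nc1ccc2c(c1)/C(=C/Nc1cccc(N3CCN(C)CC3)c1)C(=O)N2`) keeps the rest of compound 3 and alters one group, with isobutyl in place of 3-fluorophenyl on a carbonyl carbon. The aromatic ring of that group is lost, and the chain that enters is open.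

Going by the values given here, no pair of measured compounds isolates this change, so the data give no direct size or direction for it. Among the compounds with values here, the only guide is that compound 3, at 2910 nM, is the closest measured relative of compound 4. Even the structurally distant compound 1, at 1580 nM, falls within the scatter of it. A change at this one place is therefore expected to leave the reading in this assay much where it is. The expected step, a 1.2-fold lower number from compound 3 to compound 4 (0.07 log units; within the scatter), is estimated to stay within the scatter, with no firm direction. For compound 4 the estimated value is 2500 nM, with an expected range from 900 nM to 7000 nM.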

Compound 4, half-maximal inhibitory concentration: 3370 nM
Compound 4: the middle estimate sits 1.3-fold (0.13 log units) below what was measured; the range from low to high includes it.
By their numbers in this assay, from the lowest: compounds 1, 2, 3 and 4 (each within the scatter of the next, the first and the last beyond it).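

Putting isobutyl in place of 3-fluorophenyl on a carbonyl carbon gives a 1.2-fold higher number from compound 3 to compound 4 (0.06 log units; within the scatter) in this assay, and this is the first step shown between two compounds that differ in one place. It shows that, in this assay, the six-membered aromatic ring and its fluorine can give way to an open chain at this position without taking the reading beyond the scatter, so neither group can be placed ahead of the other. No measurement bears on why the reading holds across this change.

The two groups exchanged here both carry no net charge and no hydrogen-bond donors or acceptors, so the compounds shown leave open whether an amine, a carboxylic acid or a longer chain on the same carbonyl carbon would move the number beyond the scatter. They also leave open what plain phenyl would give at this position, and with it whether the fluorine counts for anything on its own.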